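The compounds below may be only part of what the source reports. "The series", "measured", "known", "first", "only" and "open" are said of these compounds alone.

The measured compounds:
Compound 1 `OCCNc1[nH]ccc2ncnc1-2` gives > 9 mg/kg in a functional assay on the whole organism (Pleural cavity) with Rattus norvegicus as the target (a lower number here means that less compound is needed, a higher number that more compound is needed for the effect), a limit of the assay rather than a number.
Compound 2 `OC[C@H]1OC(n2cnc3c(S)nccc32)[C@H](O)[C@@H]1O` gives 9 mg/kg in this assay.
Compound 3 `CN(C)c1[nH]ccc2ncnc1-2` gives 9 mg/kg in this assay.

Compound 2 stands level with compound 3 at the digits shown, a difference within the scatter, and the only other value shown, that of compound 1, is a limit (the limit of > 9 mg/kg in this assay, at which 1 of the 3 values shown sits). Within the data shown here, the single step with a measured compound at each end, a number no higher from compound 1 to compound 3 (the limit leaves the size open), has its size left open by that limit, so it tells nothing about how large a change at this position of the shared core can be.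

Compound 4 `[N-]=[N+]=Nc1nccc2c1ncn2C1O[C@H](CO)[C@@H](O)[C@H]1O` differs from compound 2 by azido in place of sulfanyl on an aromatic carbon. Among the measured compounds shown here, no measured step swaps sulfanyl or azido on any compound, so no measured step bears directly on this change. The expected step of no change at the digits printed from compound 2 to compound 4 (within the scatter) is therefore estimated as none beyond the scatter, in no particular direction. Compound 4 is expected to give about 9 mg/kg, in a range from 3 mg/kg to 27 mg/kg.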

Compound 4, dose for half-maximal effect: > 9 mg/kg
Compound 4 ended at the assay's limit; the forecaster's own chance of this, stated with the estimate: 30%; the middle value lies on the limit itself.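

Compound 4 gives > 9 mg/kg in this assay, and this value is a limit of the assay rather than a number. With azido in place of sulfanyl on this aromatic carbon, next to the ring nitrogen, the result is a number no lower from compound 2 to compound 4 (the limit leaves the size open), so this change gives a direction but no size, and no fall in the number is seen at this position. The values now offer little room for comparison, as some of them are limits: the limit of > 9 mg/kg in this assay, at which 2 of the 4 values shown sit.

Going by these compounds, how far compound 4 lies past its limit remains open, and so does the size of any change at this position. Also open, on these data alone, is how chloro or methoxy in place of sulfanyl on this aromatic carbon would read in this assay.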